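The source may hold more compounds than are shown below. What is called first, only, known or untested is meant among the compounds shown, and "the series" means these compounds.

Of the compounds shown here, two have been measured in an ADME assay on Huh-7 cells (Homo sapiens) for cytotoxicity (on this read-out lower numbers stand for higher toxicity in this test and higher numbers for lower toxicity in this test), so far. Compound 1, with the structure `CN1CCN(CCCNCc2cn(-c3ccc(C(F)(F)F)cc3)nc2-c2ccc(C(F)(F)F)cc2)CC1`, gives 2000 nM in this assay. Compound 2, with the structure `Cc1ccccc1-c1nn(-c2ccc(OC(F)(F)F)cc2)cc1CNCCN1CCN(C)CC1`, gives 17000 nM in this assay, the higher of the two numbers, and the gap between the two compounds lies beyond the usual scatter of the measurement.

Compound 3, with the structure `Cc1ccccc1-c1nn(C(C)C)cc1CNCCN1CCN(C)CC1`, has not yet been measured in this assay. It differs from compound 2 in one place: isopropyl in place of 4-(trifluoromethoxy)phenyl on an aromatic nitrogen. Within the data shown here, no pair of measured compounds differs in only one place, so nothing in the data shows directly how a swap of this kind moves the number.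

Given that, the expectation for compound 3 rests on compound 2 alone, whose 17000 nM in this assay is the starting point. The step from compound 2 to compound 3 is expected to be a 1.5-fold higher number from compound 2 to compound 3 (0.17 log units; within the scatter), which is small and may well fall within the scatter. Compound 3 is therefore estimated to give about 25000 nM in this assay, with a plausible range from 9000 nM to 70000 nM.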

Compound 3, half-maximal cytotoxic concentration: > 20000 nM
Compound 3 ended at the assay's limit (the forecaster's own chance of this, stated with the estimate: 30%); the middle value lies beyond the limit too.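

In this assay, compound 3 gives > 20000 nM, which is a limit of the assay and not a measured number. Among these compounds, replacing 4-(trifluoromethoxy)phenyl with isopropyl on the aromatic nitrogen gives an at least 1.1-fold higher number from compound 2 to compound 3 (0.07 log units; that floor lies within the scatter), with that floor within the scatter, so this is the first direct sign that the number at this position does not depend on keeping that aromatic ring. The real size of the change cannot be read, because compound 3 sits at the top of the measurable range: the limit of > 20000 nM in this assay, at which 1 of the 3 values shown sits.

Going by these compounds, it remains open whether other groups on this nitrogen, such as a methyl, a longer chain such as n-hexyl, or a chain ending in a carboxylic acid, would leave the number this high or bring it down into the measurable range. It is also unknown whether the isopropyl swap would have the same outcome with something other than the 2-methylphenyl group and the ((2-(4-methylpiperazin-1-yl)ethyl)amino)methyl group elsewhere on the ring.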